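From 3,4-dimethoxyphenyl to 4-cyanophenyl on the shared core

The source may hold more compounds than are shown below. What is called first, only, known or untested is meant among the compounds shown, and "the series" means these compounds.

Compound 1 `COc1cc(/C=C/c2ccc(NC(=O)/C=C/c3ccc(OC)c(OC)c3)cc2)cc(OC)c1`: 7740 nM
Compound 2 `COc1cc(/C=C/c2ccc(NC(=O)/C=C/c3cc(OC)c(OC)c(OC)c3)cc2)cc(OC)c1`: 2140 nM
Compound 3 `COc1cc(/C=C/c2ccc(NC(=O)/C=C/c3cc(OC)c(O)c(OC)c3)cc2)cc(OC)c1`: 7130 nM

In a functional assay on MDA-MB-231 cells (Homo sapiens) for inhibition, read by MTT assay, with a stated time of 48 h (a lower number here means a stronger inhibitor, a higher number a weaker inhibitor), compound 1 gives 7740 nM. It shares the upper end of the three numbers with one neighbour, a 1.1-fold lower number from compound 1 to compound 3 (0.04 log units; within the scatter), while the other lies lower, a 3.6-fold lower number from compound 1 to compound 2 (0.56 log units; beyond the scatter). The change to compound 4 `COc1cc(/C=C/c2ccc(NC(=O)/C=C/c3ccc(C#N)cc3)cc2)cc(OC)c1` is 4-cyanophenyl in place of 3,4-dimethoxyphenyl on a double-bonded chain carbon bound to a double-bonded chain carbon. Within the data shown here, no measured compound carries a nitrile, so the evidence is indirect. Changes on this same ring gave only modest steps, a 3.6-fold lower number from compound 1 to compound 2 (0.56 log units; beyond the scatter) and a 3.3-fold higher number from compound 2 to compound 3 (0.52 log units; beyond the scatter). No step beyond the scatter is therefore expected, and the estimated step is a 1.4-fold lower number from compound 1 to compound 4 (0.15 log units; within the scatter). Compound 4 is expected at 5500 nM, with an estimated range of 1800 nM to 16000 nM.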

Compound 4, half-maximal inhibitory concentration: 7740 nM
The estimate for compound 4 lay 1.4-fold (0.15 log units) below the measured number; low and high end bracket the measured number.
By their numbers in this assay, from the lowest: compound 2; then compounds 3, 1 and 4 (each within the scatter of the next).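

In this assay, 4-cyanophenyl in place of 3,4-dimethoxyphenyl gives (no change at the digits printed from compound 1 to compound 4 (within the scatter)), and in place of 4-hydroxy-3,5-dimethoxyphenyl it gives (a 1.1-fold higher number from compound 3 to compound 4 (0.04 log units; within the scatter)). This position therefore tolerates a ring carrying a nitrile and no oxygen substituent, with no step beyond the scatter, something the methoxy and hydroxy changes alone could not show. Nothing measured here accounts for this result. Going by these compounds, whether an amine or a carboxylic acid in place of the nitrile would also leave the number unmoved remains open. So does whether adding a methoxy to the 4-cyanophenyl ring would lower it.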